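Bromo Added to the Phenol Ring of Compound 3

The compounds below may be only part of what the source reports. "The series", "measured", "known", "first", "only" and "open" are said of these compounds alone.

Compound 3 `C=C1C[C@]23C[C@@]1(O)CC[C@H]2c1ccc(O)c(C)c1[C@@H]3Cn1cc(-c2ccccc2)nn1` carries a plain phenyl on its triazole. In a functional assay on SMMC-7721 cells (Homo sapiens) for cytotoxicity, read by MTT assay, with a stated time of 4 days (a higher number here means a weaker inhibitor, a lower number a stronger inhibitor), compound 3 gives > 20000 nM, which is a limit of the assay rather than a number. Compound 2 `C=C1C[C@]23C[C@@]1(O)CC[C@H]2c1ccc(O)c(C)c1[C@@H]3Cn1cc(-c2ccc(Br)cc2)nn1` differs by a bromo on that phenyl, and in this assay compound 2 gives > 20000 nM, again a limit. The step that the two limits leave unreadable from compound 2 to compound 3 is therefore unreadable. Compound 1 `C=C1C[C@]23C[C@@]1(O)CC[C@H]2c1cc(Br)c(O)c(C)c1[C@@H]3Cn1cc(-c2ccc(OC)cc2)nn1` carries the bromo on the phenol ring together with a methoxy on the phenyl, and in this assay compound 1 gives > 20000 nM, also a limit. Compound 4 `C=C1C[C@]23C[C@@]1(O)CC[C@H]2c1cc(Br)c(O)c(C)c1[C@@H]3Cn1cc(-c2ccccc2)nn1` differs from compound 3 by bromo in place of hydrogen on an aromatic carbon. Within the data shown here, no measured step sizes this change, because the limit of > 20000 nM in this assay, at which 3 of the 3 values shown sit, means every value so far sits at the limit. Compound 4 is therefore expected to return the limit as well, and the step that the limit leaves unreadable from compound 3 to compound 4 is estimated to stay within the scatter. Compound 4 is estimated at 30000 nM, between 10000 nM and 100000 nM.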

Compound 4, half-maximal inhibitory concentration: > 20000 nM
Compound 4 gave a limit, no number; the forecaster's own chance of this, stated with the estimate: 85%; the middle value lies beyond the limit too.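

In this assay compound 4 gives > 20000 nM, which is a limit and not a number. No new step can be read from compound 4 to compound 3 or compound 1: the limit of > 20000 nM in this assay, at which 4 of the 4 values shown sit.

The compounds shown leave open whether bromo in place of hydrogen, or any other change among them, alters the cytotoxicity at all.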